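Swapping but-3-en-1-yl for benzyl

A few compounds are considered here, and "the series" means these few. Any claim that something is new, unique, unknown or untested is made for them only; others in the source may bear on it.

Three relatives sharing one core have been tested in a functional assay on RAW264.7 cells (Mus musculus) for inhibition, read by Griess assay, with stated times of 1 h and 24 h; on this read-out higher numbers stand for weaker inhibition and lower numbers for stronger inhibition. For the measured compounds named here, compound 3 `C=CCCOc1ccc(C(O)C2OC(=O)c3c(OC)cc(OC)cc32)cc1` gives 1330 nM, the only true number among them. Compound 1 `CCC(C)Oc1ccc(C(O)C2OC(=O)c3c(OC)cc(OC)cc32)cc1` reads > 10000 nM, which is a limit and not a number. Compound 2 `COc1cc(OC)c2c(c1)C(C(O)c1ccc(OCCOc3ccccc3)cc1)OC2=O` reads > 10000 nM, which is also a limit.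

Compound 4 `COc1cc(OC)c2c(c1)C(C(O)c1ccc(OCc3ccccc3)cc1)OC2=O` is still unmeasured. Its difference from compound 3 is this: phenyl in place of allyl on a saturated chain carbon bound to an oxygen on an aromatic ring. Put simply, the but-3-en-1-yl group on the oxygen becomes benzyl.

Going by the values given here, two measured steps bear on this change. Moving from sec-butyl to but-3-en-1-yl gave an at least 7.5-fold lower number from compound 1 to compound 3 (0.87 log units; beyond the scatter). Putting vinyl in place of phenoxy gave an at least 7.5-fold lower number from compound 2 to compound 3 (0.87 log units; beyond the scatter). The remaining pair offers no guidance, as it is a step that the two limits leave unreadable from compound 1 to compound 2.

Both readable steps end at compound 3, so each of the two other groups tried on this oxygen went with a higher number. One of those groups, in compound 2, carries an aromatic ring, as benzyl does. Neither step tests benzyl itself, so the guide is loose. In this assay the expected change is a higher number, with the estimated step being a 3.4-fold higher number from compound 3 to compound 4 (0.53 log units; beyond the scatter). For compound 4 the estimated value is 4500 nM, with an expected range of 1300 nM to 15000 nM.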

Compound 4, half-maximal inhibitory concentration: > 10000 nM
Compound 4: a limit, no number; the forecaster's own chance of this, stated with the estimate: 40%; at least 2.2-fold (0.34 log units) between middle value and limit.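

On this oxygen, replacing but-3-en-1-yl with benzyl gives an at least 7.5-fold higher number from compound 3 to compound 4 (0.87 log units; beyond the scatter) in this assay, so a phenyl ring held on a single saturated carbon does not match the chain of compound 3. Across the four compounds, but-3-en-1-yl is the only group on this oxygen that gives a true number, setting compound 3 apart from the sec-butyl, 2-phenoxyethyl and benzyl relatives. The steps among compound 1, compound 2 and compound 4 cannot be read, and the three groups cannot be ranked, because all three compounds give the same limit and not a number: the limit of > 10000 nM in this assay, at which 3 of the 4 values shown sit.

The compounds shown leave open whether the lower number of compound 3 goes with the double bond of but-3-en-1-yl or simply with an unbranched chain, and a saturated n-butyl or n-pentyl group on the same oxygen would separate these two readings. Also open, from the compounds shown here alone, is whether a shorter allyl group, or a benzyl group whose ring carries a fluorine or a methoxy group, would give a true number.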